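Stereochemical variation in a furanoid butenolide series

This account rests on a few compounds, and the source may have more. Where it says the series, first, only, none or still open, it means among the compounds named here.

Two compounds of the series carry a measured value. Compound 1 `CC1=C(O)[C@@H](C/C(C)=C\CCC(C)/C=C/C=C(\C)CCCc2ccoc2)OC1=O` gives 29.7 ug/mL in a functional assay on A549 cells (Homo sapiens) for cytotoxicity; on this read-out higher numbers stand for an effect only at larger amounts of compound and lower numbers for an effect already at smaller amounts. Compound 2 `CC1=C(O)[C@@H](C/C(C)=C\CCC(C)/C=C/C/C(C)=C/CCc2ccoc2)OC1=O` gives 16.9 ug/mL in this assay. Compound 1 holds the highest of the two numbers; the nearest number belongs to compound 2, and the two values lie within the scatter of each other, so no order between them can be read. Within the data shown here, no pair of measured compounds in this set differs in one place only, so no measured step is available to calibrate a change.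

Compound 3 `CC1=C(O)[C@H](C/C(C)=C\CCC(C)/C=C\C=C(\C)CCCc2ccoc2)OC1=O` is not yet measured. Relative to compound 1 it differs as follows: the two compounds have the same atoms and bonds; at least one stereo element is drawn with a configuration in one of them and without one in the other: 3 of 5 stereo elements differ; a stereocentre at a saturated ring carbon is drawn R in compound 1 and S in compound 3; a double bond is drawn E in compound 1 and Z in compound 3; a double bond is drawn E in compound 1 and Z in compound 3. Nothing measured here shows how a change of drawn configuration shifts this read-out, so the step from compound 1 to compound 3 is expected to be a 1.0-fold higher number from compound 1 to compound 3 (0.00 log units; within the scatter), a step expected to remain within the scatter in either direction. Compound 3 is therefore expected to give about 30 ug/mL in this assay, estimated to fall between 12 ug/mL and 75 ug/mL.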

Compound 3, concentration for half-maximal effect: 10.1 ug/mL
For compound 3 the middle estimate is 3.0-fold (0.47 log units) above the measured one; measured number below the stated range.
By their numbers in this assay, from the lowest: compounds 3, 2 and 1 (each within the scatter of the next, the first and the last beyond it).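

The pair gives the series its first measured change of drawn configuration: with atoms and bonds the same, this assay shows a 2.9-fold lower number from compound 1 to compound 3 (0.47 log units; beyond the scatter). Drawn configuration alone is therefore enough to move this read-out beyond the scatter, which compounds 1 and 2 could not show, as no step links them. The step belongs to three changes taken together, at the stereocentre on the saturated ring carbon and at two double bonds, and one reservation applies to reading it as a clean comparison of configurations: the fact that one of compounds 1 and 3 is drawn with a defined configuration and the other without, at the place where they differ

Which of the three changes carries the step remains open, as does whether each acts alone or only in combination with the others. Also open, as far as these compounds go, is how the read-out would respond to a longer chain between the shared core and the chain end, or to a carboxylic acid or an amine in place of that chain end, and whether the same configurational change would then give a step of similar size and direction.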